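The source may hold more compounds than are shown below. What is called first, only, known or untested is meant among the compounds shown, and "the series" means these compounds.

Of the compounds shown here, three have so far been tested in a functional assay on MDA-MB-231 cells (Homo sapiens) for antiproliferative activity, read by sulforhodamine B assay, with a stated time of 48 h; on this read-out higher numbers stand for weaker inhibition and lower numbers for stronger inhibition. Compound 1 `COc1cc(OC)c2sc(-c3ccc(N/C=C\C(=O)c4ccc(OC)c([N+](=O)[O-])c4)c(C)c3)nc2c1` gives 10800 nM. Compound 3 `COc1cc(OC)c2sc(-c3ccc(N/C=C\C(=O)c4ccc(OC)c([N+](=O)[O-])c4)cc3)nc2c1` gives 12900 nM. Compound 2 `COc1ccc2nc(-c3ccc(N/C=C\C(=O)c4cc(OC)c(OC)c(OC)c4)c(C)c3)sc2c1` gives 17000 nM; the difference between the core of compound 2 and the core of compound 1 is not broken down here. From compound 1 to compound 3 the change is hydrogen in place of methyl on an aromatic carbon and it gave a 1.2-fold higher number from compound 1 to compound 3 (0.08 log units; within the scatter). Compound 4 `COc1ccc2nc(-c3ccc(N/C=C\C(=O)c4cc(OC)c(OC)c(OC)c4)cc3)sc2c1` has not yet been measured. It differs from compound 2 by hydrogen in place of methyl on an aromatic carbon, the same kind of change, though here the place is meta to a 6-methoxy-1,3-benzothiazol-2-yl group rather than meta to a large group. In this assay compound 4 is expected to give about 20000 nM, between 10000 nM and 40000 nM. The expected step is a 1.2-fold higher number from compound 2 to compound 4 (0.07 log units; within the scatter), resting on the measured step of a 1.2-fold higher number from compound 1 to compound 3 (0.08 log units; within the scatter) as a guide.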

Compound 4, half-maximal inhibitory concentration: 19600 nM
Compound 4: middle estimate off by 1.0-fold (0.01 log units), on the high side, and the stated range covers the measured number.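

Putting hydrogen in place of methyl on this aromatic carbon gave a 1.2-fold higher number from compound 2 to compound 4 (0.06 log units; within the scatter), and the same change can now be compared on two cores: the same change on two cores in this assay, a 1.2-fold higher number (0.08 log units; within the scatter) from compound 1 to compound 3 and a 1.2-fold higher number (0.06 log units; within the scatter) from compound 2 to compound 4, 1.0-fold (0.02 log units) apart, within the scatter of two such steps. In this assay, the change therefore behaved alike on these two cores, and neither step stands out from the usual scatter of repeated measurements. This does not show that it would behave the same way on any other core, and two steps this small cannot establish a real effect of the methyl group.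

From the compounds shown here alone, only methyl and hydrogen appear at this place, so it remains open what an ethyl group, a chlorine atom or an amine there would do to the number.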